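A few compounds are considered here, and "the series" means these few. Any claim that something is new, unique, unknown or untested is made for them only; others in the source may bear on it.

Compound 1 `Cc1ccccc1OCc1cn(-c2ccc(S(=O)(=O)N3CCc4ccccc4C3)cc2)nn1` — in an ADME assay on Vero cells (Chlorocebus sabaeus) for cytotoxicity, with a stated time of 4 days (a lower number here means a stronger inhibitor, a higher number a weaker inhibitor), compound 1 gives only a limit, > 50 ug/mL.
Compound 2 `COc1cc2c(cc1OC)CN(S(=O)(=O)c1ccc(-n3cc(COc4ccc5ccccc5c4)nn3)cc1)CC2` — in this assay compound 2 gives only a limit, > 50 ug/mL.
Compound 3 `O=S(=O)(c1ccc(-n2cc(COc3ccc4ccccc4c3)nn2)cc1)N1CCc2ccccc2C1` — in this assay compound 3 gives only a limit, > 50 ug/mL.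

All three measured values sit at the limit of > 50 ug/mL in this assay, at which 3 of the 3 values shown sit, so none of them is a number. For the measured compounds named here, the single step between measured compounds that differ in one place, a step that the two limits leave unreadable from compound 1 to compound 3, has no readable size since both of its ends are limits. Compound 2 therefore stands only at a limit in this assay, on a level with the other two measured compounds, and no order among them can be drawn.

Compound 4 `COc1cc2c(cc1OC)CN(S(=O)(=O)c1ccc(-n3cc(COc4ccc(C=O)cc4OC)nn3)cc1)CC2` differs from compound 2 by 4-formyl-2-methoxyphenyl in place of naphthalen-2-yl on an oxygen on a saturated carbon. No measured step bears directly on this change; the one step shown swaps a different pair of aryl groups on the same oxygen and is itself unreadable. With no evidence of any step beyond the scatter, compound 2 is expected to pass its limit on to compound 4 without a readable change, so the step of a number no higher from compound 2 to compound 4 (the limit leaves the size open) is estimated to be nil. Compound 4 is therefore estimated to give 50 ug/mL, within a range from 30 ug/mL to 100 ug/mL, most likely reported as a limit.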

Compound 4, half-maximal inhibitory concentration: > 50 ug/mL
Compound 4: a limit, no number; the forecaster's own chance of this, stated with the estimate: 85%; the middle value lies on the limit itself.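

Compound 2 and compound 4 both give only a limit in this assay, so no step can be read between them: the limit of > 50 ug/mL in this assay, at which 4 of the 4 values shown sit.

The compounds shown leave open where any of them would give an actual number, and whether changing the aryl group on the oxygen alters cytotoxicity at all.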